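Arginine-type side chain replaces sec-butyl on a purine series

The source may report more compounds than this note shows. Statements on the series, on what has been measured and on what is new or still open speak of the compounds shown alone.

Of the compounds shown here, three of one series have been tested in a functional assay on the whole organism (Tail, strain ICR) with Mus musculus as the target, in the tail flick test, with a stated time of 60 min, at a dose of 25 umol/kg by the oral route; on this read-out higher numbers stand for a stronger effect at the one dose given and lower numbers for a weaker effect. Among the measured compounds shown here, compound 1 `O=C(CN(c1nc(Cl)nc2[nH]cnc12)C1CC1)NCC(=O)OCc1ccccc1` gives 41.9%, and compound 3 `O=C(O)CNC(=O)CN(c1nc(Cl)nc2[nH]cnc12)C1CC1`, which carries hydrogen in place of benzyl on an oxygen next to a carbonyl group, gives 38.9%; the step of a number 3 percentage points lower from compound 1 to compound 3 (within the scatter) is the only single-point change measured so far. Compound 2 `CC[C@H](C)[C@H](NC(=O)CN(c1ncnc2c1ncn2C1CCCCO1)C1CC1)C(=O)OCc1ccccc1` gives 27.4%, the lowest of the three numbers, and its gaps to compound 3 and to compound 1 both lie beyond the scatter.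

Compound 4 `N=C(N)NCCC[C@H](NC(=O)CN(c1ncnc2c1ncn2C1CCCCO1)C1CC1)C(=O)OCc1ccccc1` differs from compound 2 in one place: a group of 7 heavy atoms (4 carbon, 3 nitrogen; no ring) in place of a group of 4 heavy atoms (4 carbon; no ring), on a saturated chain carbon bound to an amide-type nitrogen and a carbonyl carbon. For the measured compounds named here, no measured step touches this position or either of these groups, and the single measured step, which sits elsewhere on the molecule, was itself within the scatter, so it offers no guide to direction. Going by the values given here, the only anchor is the value of compound 2 itself, and the expectation therefore rests on that alone, with a wide range to admit a movement either way.

On that basis compound 4 is expected to give about 30% in this assay, between 12% and 52%, so that the expected step is a number 2.6 percentage points higher from compound 2 to compound 4 (within the scatter).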

Compound 4, a percentage reported as activity, at one dose (the size of the read-out at that dose, not a potency): 52.4%
For compound 4 the middle estimate is 22.4 percentage points below the measured one, outside the stated range (above it).
By their numbers in this assay, from the lowest: compound 2; then compounds 3 and 1 (each within the scatter of the next); then compound 4.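

In this assay, the saturated chain carbon bound to an amide-type nitrogen and a carbonyl carbon proves responsive to the group it carries, with a number 25 percentage points higher from compound 2 to compound 4 (beyond the scatter). Among the compounds shown here, this is the first single-place change to lie beyond the scatter, since the one earlier step, made elsewhere on the molecule, stayed within it. It shows that sec-butyl can be exchanged here for a longer, nitrogen-bearing group of 7 heavy atoms with 3 hydrogen-bond donors and that the number rises at the one dose given, although nothing measured on these compounds accounts for the rise.

Going by these compounds, a single pair cannot separate the contribution of the added nitrogen atoms from that of the longer chain, so it remains open whether a plain n-butyl chain or a chain ending in a primary amine at this position would reach the level of compound 4. On these data alone, it also remains open whether the same exchange would give a step of similar size with a free carboxylic acid in place of the benzyl ester, or on the chlorine-bearing core of compound 1.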